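The compounds below may be only part of what the source reports. "The series", "measured", "known", "first", "only" and "open" are said of these compounds alone.

Measured so far:
- compound 1 `O=C(Cc1csc2nc(-c3ccc(Br)cc3)cn12)N/N=C/c1ccccc1`: 12900 nM
- compound 2 `O=C(Cc1csc2nc(-c3ccc(Br)cc3)cn12)N/N=C/c1ccccc1O`: 10000 nM

In a functional assay on BT-549 cells (Homo sapiens) for inhibition, read by sulforhodamine B assay, with a stated time of 48 h (on this read-out higher numbers stand for weaker inhibition of growth and lower numbers for stronger inhibition of growth), compound 2 gives 10000 nM and cannot be told apart from compound 1, which gives 12900 nM. Compound 3 `O=C(Cc1csc2nc(-c3ccc(Br)cc3)cn12)N/N=C/c1ccc(O)cc1` is the next member to consider. It carries 4-hydroxyphenyl in place of 2-hydroxyphenyl on a carbon with a double bond to nitrogen.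

Going by the values given here, only one measured step bears on this change: a 1.3-fold lower number from compound 1 to compound 2 (0.11 log units; within the scatter). That step is hydroxy in place of hydrogen on an aromatic carbon. Among the compounds with values here, it shows that adding the hydroxy group as in compound 2 left the number within the scatter, but it does not test the 4-hydroxyphenyl group, and no measured compound carries that group. The evidence is therefore thin, and it gives no ground for expecting a large move in either direction in this assay. The expected outcome is a 1.1-fold higher number from compound 2 to compound 3 (0.04 log units; within the scatter), with no step beyond the scatter anticipated. For compound 3 the expected value is 11000 nM, with an estimated range from 4500 nM to 25000 nM.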

Compound 3, concentration for 50% growth inhibition: 13500 nM
Beside the measured number, compound 3's estimate is 1.2-fold (0.09 log units) below it; low and high end bracket the measured number.
By their numbers in this assay, from the lowest: compounds 2, 1 and 3 (each within the scatter of the next).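

Working notes on the series: in this assay, 4-hydroxyphenyl in place of 2-hydroxyphenyl on a carbon with a double bond to nitrogen gives a 1.4-fold higher number from compound 2 to compound 3 (0.13 log units; within the scatter) for this read-out, so the two hydroxyphenyl isomers cannot be told apart here. The comparison with the parent gives a 1.0-fold higher number from compound 1 to compound 3 (0.02 log units; within the scatter) for hydroxy in place of hydrogen on an aromatic carbon, so neither hydroxyphenyl compound can be separated from compound 1, and the series now has two placements of the hydroxy group on this ring that leave the number within the scatter. Nothing available here accounts for these numbers.

The compounds shown cover only hydrogen and hydroxy as ring substituents, so it remains open whether a methoxy group, an amine or a carboxylic acid at this ring would give a step beyond the scatter. Also open, from the compounds shown here alone, is how far the number depends on the rest of the shared core, such as the bromo substituent or the chain carrying the carbonyl, since all three compounds keep these parts unchanged.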